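This account rests on a few compounds, and the source may have more. Where it says the series, first, only, none or still open, it means among the compounds named here.

Measured compounds in the series:
- compound 1, `Cc1ccc(CSc2n[nH]c(-n3[se]c4ccccc4c3=O)n2)cc1`, 34800 nM
- compound 2, `Cc1cccc(CSc2n[nH]c(-n3[se]c4ccccc4c3=O)n2)c1`, 42600 nM

Both compounds were characterised in a functional assay on HeLa cells (Homo sapiens) for antiproliferative activity, read by CCK-8 assay, with a stated time of 48 h; on this read-out higher numbers stand for weaker inhibition and lower numbers for stronger inhibition. Compound 2 holds the highest number of the two; its nearest neighbour is compound 1, and the step of a 1.2-fold higher number from compound 1 to compound 2 (0.09 log units; within the scatter) lies within the scatter, so the two compounds are not separated on this read-out.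

Compound 3, `CC(C)Sc1n[nH]c(-n2[se]c3ccccc3c2=O)n1`, differs from compound 2 by one change: isopropyl in place of 3-methylbenzyl on a sulfur. Among the compounds with values here, the only measured step, a 1.2-fold higher number from compound 1 to compound 2 (0.09 log units; within the scatter), moves a methyl within the ring of the benzyl group and leaves the benzyl itself in place; it does not bear directly on the exchange of the whole 3-methylbenzyl for isopropyl. Within the data shown here, there is thus no measured precedent for this change, and the two values give only a baseline in the weak range. A step of no more than the scatter, in either direction, is expected, with a wider range allowed for the lack of precedent; the step expected from compound 2 to compound 3 is a 1.1-fold higher number from compound 2 to compound 3 (0.02 log units; within the scatter). In this assay compound 3 is estimated at 45000 nM, within 15000 nM to 130000 nM.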

Compound 3, half-maximal inhibitory concentration: 34600 nM
Compound 3: the middle estimate sits 1.3-fold (0.11 log units) above what was measured; low and high end bracket the measured number.
By their numbers in this assay, from the lowest: compounds 3, 1 and 2 (each within the scatter of the next).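

In this assay, replacing the whole 3-methylbenzyl with isopropyl on the sulfur gives a 1.2-fold lower number from compound 2 to compound 3 (0.09 log units; within the scatter), and replacing 4-methylbenzyl with the same group gives a 1.0-fold lower number from compound 1 to compound 3 (0.00 log units; within the scatter); both steps lie within the scatter. The earlier pair covered only a shift of the methyl group with the benzyl kept in place, whereas these steps show that, among these three compounds, removing the six-membered aromatic ring of carbon and going from 8 heavy atoms to 3 at this position does not separate the compounds on this read-out. No supporting evidence bears on this result, so the lack of separation remains an observation without an explanation.

The compounds shown leave open whether an amine or a carboxylic acid on the sulfur, or a longer chain there, would give a step beyond the scatter from compound 3. They also leave open whether any change to the shared core, rather than to the group on the sulfur, would separate a compound from these three in this assay.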